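The source may hold more compounds than are shown below. What is called first, only, known or untested is meant among the compounds shown, and "the series" means these compounds.

Measured in a functional assay on SK-BR-3 cells (Homo sapiens) for antiproliferative activity; on this read-out higher numbers stand for weaker inhibition and lower numbers for stronger inhibition:
- compound 1 `CC(C)=CCc1cc(C(=O)Nc2cc3ccc(OCCCN4CCCCC4)c(C)c3oc2=O)ccc1O`: > 50000 nM
- compound 2 `CC(C)=CCc1cc(C(=O)Nc2cc3ccc(OCCCN4CCCC4)c(C)c3oc2=O)ccc1O`: 720 nM

The reading for compound 1 is a limit and not a number. Going by the values given here, compound 2, at 720 nM, is the only compound here with a true number, so it is the sole measured anchor in this assay.

The unmeasured compound 3 `CCCN(CCC)CCCOc1ccc2cc(NC(=O)c3ccc(O)c(CC=C(C)C)c3)c(=O)oc2c1C` keeps the shared core and differs from compound 2 in the amine alone: dipropylamino in place of pyrrolidin-1-yl on a saturated chain carbon, three bonds along the chain from an oxygen on an aromatic ring. It carries dipropylamino in place of pyrrolidin-1-yl on a saturated chain carbon, three bonds along the chain from an oxygen on an aromatic ring.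

Among the compounds with values here, one measured step bears on this place: an at least 69-fold lower number from compound 1 to compound 2 (1.84 log units; beyond the scatter). It is large and beyond the scatter, and it shows that activity here depends strongly on which amine is present. That step involves piperidin-1-yl, however, and dipropylamino has no ring, so it offers only a loose guide. A move to a higher number is expected in this assay, probably smaller than that step.

For compound 3 the expected value is 4000 nM, with an estimated range of 700 nM to 35000 nM. The expected change is a 5.6-fold higher number from compound 2 to compound 3 (0.74 log units; beyond the scatter).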

Compound 3, half-maximal inhibitory concentration: > 50000 nM
Compound 3: no number, only a limit; the forecaster's own chance of this, stated with the estimate: 20%; middle value at least 12-fold (1.09 log units) away from the limit.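

In this assay, going from 3-(pyrrolidin-1-yl)propyl to 3-(dipropylamino)propyl gives an at least 69-fold higher number from compound 2 to compound 3 (1.84 log units; beyond the scatter), a large step beyond the scatter. Before this result, piperidin-1-yl was the only other amine set against pyrrolidin-1-yl, so the absence of a measured number could have been peculiar to that one ring. It now also appears with an amine that has no ring, and among the three amines shown, only pyrrolidin-1-yl gives a true number. Compound 3 gives a limit and not a number, so its step to compound 1 cannot be read, and both compounds stand at the same boundary: the limit of > 50000 nM in this assay, at which 2 of the 3 values shown sit.

From the compounds shown here alone, how far compound 1 and compound 3 lie past that limit remains unknown, so their amines cannot be placed in order. Going by these compounds, it also remains open whether dimethylamino, azetidin-1-yl or morpholin-4-yl on the same propyl chain, or pyrrolidin-1-yl on a longer chain, would stay close to compound 2 at 720 nM.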